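The compounds below may be only part of what the source reports. "The series", "measured", "known", "first", "only" and "open" are said of these compounds alone.

Compound 1 `COc1ccc(C(=O)/C=C/c2cc(-c3ccc(OC)c(OC)c3)n3nc(-c4ccccc4)cc3n2)cc1OC` is the reference point. In a functional assay on DU-145 cells (Homo sapiens) for antiproliferative activity, read by MTT assay, with a stated time of 24 h (on this read-out higher numbers stand for weaker inhibition and lower numbers for stronger inhibition), compound 1 gives 7200 nM. Compound 2 `COc1ccc(-c2cc(/C=C/C(=O)c3ccc(Cl)cc3)nc3cc(-c4ccccc4)nn23)cc1OC` carries one change, (4-chlorophenyl in place of 3,4-dimethoxyphenyl on a carbonyl carbon), and in this assay compound 2 gives 21300 nM, so that a 3.0-fold higher number from compound 1 to compound 2 (0.47 log units; beyond the scatter). Compound 3 `COc1ccc(C(=O)/C=C/c2cc(-c3cc(OC)c(OC)c(OC)c3)n3nc(-c4ccccc4)cc3n2)cc1OC` differs from compound 1 at a different spot; in this assay compound 3 gives 29900 nM, which means a 4.2-fold higher number from compound 1 to compound 3 (0.62 log units; beyond the scatter). Compound 4 `COc1cc(-c2cc(/C=C/C(=O)c3ccc(Cl)cc3)nc3cc(-c4ccccc4)nn23)cc(OC)c1OC` has not yet been tested in this assay. It differs from compound 3 by 4-chlorophenyl in place of 3,4-dimethoxyphenyl on a carbonyl carbon, and the place where this change sits is described in the same words for both pairs, so it is the same change already seen between compound 1 and compound 2. The cores of compound 3 and compound 4 differ from those of compound 1 and compound 2 by methoxy in place of hydrogen on an aromatic carbon. Each change on its own gave a higher number, so compound 4 is expected to lie further in that direction. Carrying the earlier step over, the estimate for compound 4 is a step of a 2.8-fold higher number from compound 3 to compound 4 (0.45 log units; beyond the scatter), which rests on the same change having produced a 3.0-fold higher number from compound 1 to compound 2 (0.47 log units; beyond the scatter). In this assay compound 4 is therefore expected to give about 85000 nM, with a plausible range from 28000 nM to 250000 nM.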

Compound 4, half-maximal inhibitory concentration: 29300 nM
Compound 4: the middle estimate sits 2.9-fold (0.46 log units) above what was measured, within the range that was stated.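

On the core of compound 3, putting 4-chlorophenyl in place of 3,4-dimethoxyphenyl on the carbonyl carbon gave a 1.0-fold lower number from compound 3 to compound 4 (0.01 log units; within the scatter) in this assay, and adding the methoxy to the core of compound 2 gave a 1.4-fold higher number from compound 2 to compound 4 (0.14 log units; within the scatter). The step seen for the 4-chlorophenyl swap on the core of compound 1 therefore did not carry over to the core of compound 3: the same change on two cores in this assay, a 3.0-fold higher number (0.47 log units; beyond the scatter) from compound 1 to compound 2 and a 1.0-fold lower number (0.01 log units; within the scatter) from compound 3 to compound 4, 3.0-fold (0.48 log units) apart, beyond the scatter of two such steps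

The added methoxy gives the same picture, although four compounds cannot say why the steps differ or whether this holds elsewhere in the series: the same change on two cores in this assay, a 4.2-fold higher number (0.62 log units; beyond the scatter) from compound 1 to compound 3 and a 1.4-fold higher number (0.14 log units; within the scatter) from compound 2 to compound 4, 3.0-fold (0.48 log units) apart, beyond the scatter of two such steps

On these data alone, it remains open whether other groups on the carbonyl carbon, such as 4-fluorophenyl or a phenyl ring bearing an amine, would also depend on the core in this way. As far as these compounds go, it is equally open whether a carboxylic acid or a longer chain in place of the methoxy would show the same dependence on the group at the carbonyl.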